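The source may report more compounds than this note shows. Statements on the series, on what has been measured and on what is new or still open speak of the compounds shown alone.

Measured in a functional assay on HepG2 cells (Homo sapiens) for antiproliferative activity, read by MTT assay, with a stated time of 48 h; a higher number here means a weaker inhibitor, a lower number a stronger inhibitor:
compound 1 `O=C(Nc1cccc(Cl)c1)Nc1cccc(CNc2nccnc2Cl)c1`: 9140 nM
compound 2 `O=C(Nc1cccc(CNc2nccnc2Cl)c1)Nc1ccc(Cl)cc1Cl`: 7230 nM
compound 3 `O=C(Nc1cccc(CNc2nccnc2Cl)c1)NC1CCCCC1`: > 40000 nM, a limit and not a number

Compound 3 stands at the limit of > 40000 nM in this assay, at which 1 of the 3 values shown sits. The next compound is compound 4 `Cc1ccc(NC(=O)Nc2cccc(CNc3nccnc3Cl)c2)cc1Cl`, with 3-chloro-4-methylphenyl in place of cyclohexyl on an amide-type nitrogen.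

Two measured steps make the reverse kind of change, putting cyclohexyl in place of a chlorinated phenyl group at that nitrogen. They are an at least 4.3-fold higher number from compound 1 to compound 3 (0.64 log units; beyond the scatter) and an at least 5.5-fold higher number from compound 2 to compound 3 (0.74 log units; beyond the scatter). Both lie beyond the scatter, and both give only a minimum size, since one end of each is a limit. The exchange of one chlorinated phenyl group for another, a 1.3-fold lower number from compound 1 to compound 2 (0.10 log units; within the scatter), stays within the scatter.

Compound 4 is therefore expected to fall in the range of compound 1 and compound 2, giving a lower number in this assay and a step of modest size or more. The expected step is an at least 5.0-fold lower number from compound 3 to compound 4 (0.69 log units; beyond the scatter). Within the data shown here, no measured compound carries 3-chloro-4-methylphenyl, so the range is kept fairly wide. The estimate for compound 4 is 8000 nM, with an expected range from 3500 nM to 18000 nM.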

Compound 4, half-maximal inhibitory concentration: 11300 nM
Estimate against measurement, compound 4: 1.4-fold (0.15 log units) below; measured number inside the range.
By their numbers in this assay, from the lowest: compounds 2, 1 and 4 (each within the scatter of the next). At a limit, above all of these: compound 3.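

In this assay, putting 3-chloro-4-methylphenyl in place of cyclohexyl on an amide-type nitrogen gives an at least 3.5-fold lower number from compound 3 to compound 4 (0.54 log units; beyond the scatter) and extends the separation from cyclohexyl to a third chlorinated phenyl group, so it no longer rests on compound 1 and compound 2 alone. Methyl in place of hydrogen on an aromatic carbon gives a 1.2-fold higher number from compound 1 to compound 4 (0.09 log units; within the scatter) and 3-chloro-4-methylphenyl in place of 2,4-dichlorophenyl gives a 1.6-fold higher number from compound 2 to compound 4 (0.19 log units; within the scatter) so neither change separates these chlorinated phenyl compounds from one another in this assay. Compound 3 remains a limit and not a number, so the cyclohexyl step has only a minimum size: the limit of > 40000 nM in this assay, at which 1 of the 4 values shown sits.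

The compounds shown leave open whether an unsubstituted phenyl group, or a phenyl group carrying methoxy, a dimethylamino group or a carboxylic acid, would stay in the range of compounds 1, 2 and 4. They also leave open whether an open chain such as n-butyl on the same nitrogen would behave like cyclohexyl or like the chlorinated phenyl groups.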